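The source may hold more compounds than are shown below. What is called first, only, known or untested is meant among the compounds shown, and "the series" means these compounds.

Working notes on the series, read in a functional assay on K562 cells (Homo sapiens) for cytotoxicity, read by MTT assay, with a stated time of 5 days; on this read-out lower numbers stand for stronger inhibition and higher numbers for weaker inhibition. Compound 1 (`COc1ccc(-c2cn(-c3cc(OC)c(OC)c(OC)c3)nn2)cc1Br`) gives > 10000 nM, which is a limit and not a number. Compound 2 (`COc1ccc(-c2cn(-c3cc(OC)c(OC)c(OC)c3)nn2)cc1O`) gives > 10000 nM, again a limit. Compound 3 (`COc1ccc(-c2cn(-c3cc(OC)c(OC)c(OC)c3)nn2)cc1[N+](=O)[O-]`) gives > 10000 nM, also a limit, so it has no number of its own. Among the compounds with values here, the series so far stands at the limit of > 10000 nM in this assay, at which 3 of the 3 values shown sit.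

The next change leads to compound 4 (`COc1ccc(-c2cn(-c3cc(OC)c(OC)c(OC)c3)nn2)cc1N`): amino in place of nitro on an aromatic carbon, ortho to a methoxy group (amino in place of nitro on an aromatic carbon). Three exchanges at the same place bear on it: a step that the two limits leave unreadable from compound 1 to compound 2, a step that the two limits leave unreadable from compound 1 to compound 3 and a step that the two limits leave unreadable from compound 2 to compound 3. None of them gives a size to carry over. With the bromo, hydroxy and nitro compounds all at the limit, and with compound 3 at > 10000 nM, no step beyond the scatter is expected in this assay, though the direction cannot be read from these data. The estimated step is a number no higher from compound 3 to compound 4 (the limit leaves the size open). For compound 4 the estimated value is 10000 nM, with an expected range from 2500 nM to 30000 nM.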

Compound 4, half-maximal inhibitory concentration: 1300 nM
Compound 4: middle estimate off by 7.7-fold (0.89 log units), on the high side; measured number below the stated range.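

In this assay, amino is the only group shown at this position that brings a number inside the measured range, with an at least 7.6-fold lower number from compound 3 to compound 4 (0.88 log units; beyond the scatter), an at least 7.6-fold lower number from compound 2 to compound 4 (0.88 log units; beyond the scatter) and an at least 7.6-fold lower number from compound 1 to compound 4 (0.88 log units; beyond the scatter). The position ortho to a methoxy group is therefore not indifferent to its substituent, which compound 1, compound 2 and compound 3 could not show, since the steps among those three cannot be read. Each of the three new steps gives only a minimum size, and the earlier compounds stay unordered, with the series still resting largely on one limit: the limit of > 10000 nM in this assay, at which 3 of the 4 values shown sit.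

Open, as far as these compounds go, is whether a methylamino group, an acetamido group or an aminomethyl group at this position would hold the number of compound 4. Also open, from the compounds shown here alone, is whether amino would give a comparable step on another position of the same ring.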